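This account rests on a few compounds, and the source may have more. Where it says the series, first, only, none or still open, it means among the compounds named here.

Going by the values given here, compound 2 `COc1ccc(C(=O)N=C(N)N)cc1S(C)(=O)=O` stands at the higher of the two numbers measured so far: in a functional assay for inhibition of sodium/hydrogen exchanger (Oryctolagus cuniculus) (on this read-out lower numbers stand for stronger inhibition and higher numbers for weaker inhibition), compound 2 gives 270 nM. Among the compounds with values here, its only measured companion is compound 1 `Cc1cc(C2CCCCC2)c(S(C)(=O)=O)cc1C(=O)N=C(N)N`, which in this assay gives 22 nM, a lower number and therefore a stronger inhibitor, and the gap between the two lies beyond the usual scatter. Within the data shown here, no single-point step between measured compounds exists in this set, so what follows rests on these two values and on the structural change alone. The unmeasured compound 3 `CS(=O)(=O)c1cc(C(=O)N=C(N)N)ccc1C1CCCCC1` differs from compound 2 in one place: cyclohexyl in place of methoxy on an aromatic carbon. With that change compound 3 carries the same cyclohexyl group that compound 1 carries, though without the methyl group found in compound 1. A step toward a lower number, beyond the scatter, seems likely, since compound 1 with its cyclohexyl gives 22 nM. For compound 3 the expected step is a 6.0-fold lower number from compound 2 to compound 3 (0.78 log units; beyond the scatter). The estimate for compound 3 in this assay is 45 nM, with a range from 15 nM to 140 nM.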

Compound 3, half-maximal inhibitory concentration: 340 nM
Beside the measured number, compound 3's estimate is 7.6-fold (0.88 log units) below it, and the stated range ends below it.
By their numbers in this assay, from the lowest: compound 1; then compounds 2 and 3 (each within the scatter of the next).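

In this assay, putting cyclohexyl in place of methoxy on the aromatic carbon ortho to the methylsulfonyl group gives a 1.3-fold higher number from compound 2 to compound 3 (0.10 log units; within the scatter), so this read-out does not separate the two groups at this position, even though cyclohexyl brings 6 heavy atoms and a ring where methoxy has 2 heavy atoms and no ring. Cyclohexyl alone therefore does not account for the low number of compound 1: with cyclohexyl held in place, hydrogen in place of methyl on an aromatic carbon gives a 15-fold higher number from compound 1 to compound 3 (1.19 log units; beyond the scatter), a large step that points to the methyl group as the change that matters between these two compounds. Nothing available here explains why one change leaves the number in place and the other moves it so far.

The compounds shown leave open whether methyl would give a step of similar size with methoxy in place of cyclohexyl, as its step is seen only alongside cyclohexyl. They also leave open how an amine or a cyclopentyl group at this position would read in this assay.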